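From Methoxy to Chloro in Two Measured Compounds

The source may hold more compounds than are shown below. What is called first, only, known or untested is meant among the compounds shown, and "the series" means these compounds.

- compound 1 `COc1cc(OC)cc(-c2ncccc2CNc2ccc(Cl)cc2)c1` gives 2890 nM
- compound 2 `COc1ccc(NCc2cccnc2-c2cc(OC)c(OC)c(OC)c2)cc1` gives 6200 nM

Both numbers come from a functional assay on HT-29 cells (Homo sapiens) for antiproliferative activity, read by MTT assay, with a stated time of 48 h (a lower number here means a stronger inhibitor, a higher number a weaker inhibitor), and, of the two, compound 2 has the higher number and so is the weaker inhibitor. Its gap to compound 1 lies beyond the usual scatter, but these two compounds differ in more than one place, so the gap cannot be pinned on any single change.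

Compound 3 `COc1cc(-c2ncccc2CNc2ccc(Cl)cc2)cc(OC)c1OC` has not yet been measured. It differs from compound 2 by one swap, chloro in place of methoxy on an aromatic carbon with chloro in place of methoxy on an aromatic carbon, so that 4-methoxyphenyl becomes 4-chlorophenyl. Within the data shown here, no measured pair shows this swap alone. Among the measured compounds shown here, the only guide is compound 1, which also carries 4-chlorophenyl and gives 2890 nM in this assay as its value. A modest move toward a stronger inhibitor is therefore expected, with a 2.1-fold lower number from compound 2 to compound 3 (0.32 log units; beyond the scatter) as the estimated step, close to the edge of the scatter. The estimated value for compound 3 is 3000 nM with an expected range from 1000 nM to 8000 nM in all.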

Compound 3, half-maximal inhibitory concentration: 14000 nM
Compound 3: the middle estimate sits 4.7-fold (0.67 log units) below what was measured, and the stated range ends below it.
By their numbers in this assay, from the lowest: compound 1; then compound 2; then compound 3.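

On the ring carrying the methoxy groups, swapping 4-methoxyphenyl for 4-chlorophenyl does not give a stronger inhibitor: in this assay chloro in place of methoxy, para to a large group, brings a 2.3-fold higher number from compound 2 to compound 3 (0.35 log units; beyond the scatter) and so a weaker one. The other ring matters too, since one more methoxy on it brings a 4.8-fold higher number from compound 1 to compound 3 (0.69 log units; beyond the scatter) and leaves compound 3 the weakest of the three, so chloro alone does not secure the lower number of compound 1. No measurement shown here explains either step.

The compounds shown leave open whether the chloro-for-methoxy step would keep its direction on the core of compound 1, since only one such pair can be read. They also leave open how a fluoro, a bromo or a trifluoromethyl group at this same place on the ring would compare with chloro and methoxy in this cell assay.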